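Swapping one pyridinyl group for another

The source may report more compounds than this note shows. Statements on the series, on what has been measured and on what is new or still open speak of the compounds shown alone.

Of the compounds shown here, three have been measured in an in vitro functional assay on HEK285-7 cells for antagonist activity at prostaglandin D2 receptor 2 (Homo sapiens), read by BRET and beta-arrestin recruitment; on this read-out higher numbers stand for weaker inhibition and lower numbers for stronger inhibition. Compound 1 `O=C(O)Cc1sc(COc2ccc(Cl)cc2)nc1-c1ccc(Cl)cc1` gives 370 nM. Compound 3 `O=C(O)Cc1sc(C(c2ccccc2)c2ccccc2)nc1-c1ccc(F)c(F)c1` gives 43 nM. Going by the values given here, compound 2 `O=C(O)Cc1sc(C(c2ccc(F)cc2)c2ccc(F)cc2)nc1-c1ccnc(N2CCC2)c1` gives no number in this assay: its result is only a limit, > 100000 nM, and it is the one value of the three that sits at the limit of > 100000 nM in this assay, at which 1 of the 3 values shown sits. So compound 2 stands apart from compound 1 and compound 3, which both give measured values.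

Compound 4 `Cc1cc(-c2nc(C(c3ccc(F)cc3)c3ccc(F)cc3)sc2CC(=O)O)cnc1N` has not yet been measured. It differs from compound 2 in one place: 6-amino-5-methylpyridin-3-yl in place of 2-(azetidin-1-yl)pyridin-4-yl on an aromatic carbon. Among the compounds with values here, no measured pair of compounds differs in only one place, so there is no measured step to lean on. Both compound 1 and compound 3 carry a substituted phenyl group where compound 2 carries its pyridinyl group, and both give numbers in this assay, while compound 2 does not. The expectation is a gain in inhibition, as the step from compound 2 to compound 4 is expected to be an at least 20-fold lower number from compound 2 to compound 4 (1.30 log units; beyond the scatter), with wide uncertainty. Compound 4 is expected to give about 5000 nM, estimated to lie between 500 nM and 100000 nM.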

Compound 4, half-maximal inhibitory concentration: > 100000 nM
Compound 4 gave a limit, no number; the forecaster's own chance of this, stated with the estimate: 35%; middle value at least 20-fold (1.30 log units) from the limit.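

Compound 2 and compound 4 both give only a limit in this assay, not a number, so no step can be read between them: the limit of > 100000 nM in this assay, at which 2 of the 4 values shown sit.

The compounds shown leave open whether 6-amino-5-methylpyridin-3-yl in place of 2-(azetidin-1-yl)pyridin-4-yl changes inhibition at all.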